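This account rests on a few compounds, and the source may have more. Where it says the series, first, only, none or still open, it means among the compounds named here.

Measured compounds:
compound 1 `O=C(/C=C/c1ccc2c(c1)B(O)OC2)c1ccccc1`: 6100 nM
compound 2 `O=C(/C=C/c1ccc2c(c1)B(O)OC2)c1ccc(O)cc1`: 24100 nM

Among the measured compounds shown here, in a functional assay on HCT-116 cells (Homo sapiens) for cytotoxicity, read by MTT assay, with a stated time of 48 h (on this read-out lower numbers stand for stronger inhibition and higher numbers for weaker inhibition), compound 1 gives the lowest of these two numbers; the only other compound, compound 2, gives a higher number, a 4.0-fold higher number from compound 1 to compound 2 (0.60 log units; beyond the scatter). Compound 3 `O=C(/C=C/c1ccc2c(c1)B(O)OC2)c1ccccc1O` differs from compound 1 by hydroxy in place of hydrogen on an aromatic carbon. For the measured compounds named here, the one measured step that bears on this is a 4.0-fold higher number from compound 1 to compound 2 (0.60 log units; beyond the scatter), which is also hydroxy in place of hydrogen on an aromatic carbon, so a modest rise is expected, a 2.0-fold higher number from compound 1 to compound 3 (0.29 log units; within the scatter). For compound 3 the estimate is 12000 nM, with a range from 4000 nM to 40000 nM.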

Compound 3, half-maximal inhibitory concentration: 77900 nM
Compound 3: middle estimate off by 6.5-fold (0.81 log units), on the low side, and the stated range ends below it.
By their numbers in this assay, from the lowest: compound 1; then compound 2; then compound 3.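

The 2-hydroxyphenyl group shows that the same swap of hydrogen for hydroxy can cost far more than the 4-hydroxyphenyl group suggested, with a 13-fold higher number from compound 1 to compound 3 (1.11 log units; beyond the scatter) in this assay as the large step. Where the hydroxy sits therefore matters in its own right, as a 3.2-fold higher number from compound 2 to compound 3 (0.51 log units; beyond the scatter) separates the two hydroxyphenyl compounds beyond the scatter. Adding hydroxy raised the number at both places shown, so neither hydroxyphenyl compound improves on compound 1.

From the compounds shown here alone, whether a methoxy group or an amine at these places would keep the number near that of compound 1 remains open. Nothing available here explains why the two placements differ.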